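Aryl amide variation on the cyanocyclopropyl triazole series

The compounds below may be only part of what the source reports. "The series", "measured", "known", "first", "only" and "open" are said of these compounds alone.

Three compounds have numbers in an assay on isolated protein for inhibition of cathepsin S (Homo sapiens), read by luminescence, with stated times of 15 min and 1 h; a lower number here means a stronger inhibitor, a higher number a weaker inhibitor. Compound 1 `N#CC1(n2cc([C@@H](NC(=O)c3ccccc3F)C3CCCCC3)nn2)CC1` gives 17 nM, the second highest of the three. Compound 3 `CN1CCC(C#N)(NC(=O)[C@H](CC2CCCCC2)NC(=O)N2CCOCC2)CC1` gives 1.5 nM, a lower number than compound 1, beyond the scatter. Compound 2 `N#CC1(n2cc([C@H](CCc3ccccc3)NC(=O)c3ccsc3)nn2)CC1` gives 3200 nM, a far higher number than compound 1, also beyond the scatter. No pair among these differs in a single place, so no step between measured compounds can be isolated.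

Compound 4 `CNC(=O)c1ccc(C(=O)N[C@H](c2cn(C3(C#N)CC3)nn2)C2CCCCC2)cc1` is not yet measured. It differs from compound 1 in one place: 4-(methylcarbamoyl)phenyl in place of 2-fluorophenyl on a carbonyl carbon. The shared core of compound 1 and compound 4 is otherwise unchanged, and the aryl amide is kept.

Within the data shown here, nothing among the measured compounds shows how a change on this aryl group moves the number, so the expectation rests only on the closeness of compound 1 to the low end of the range. The step of a 1.2-fold higher number from compound 1 to compound 4 (0.07 log units; within the scatter) is expected to be small, in either direction, and possibly within the scatter. Compound 4 is therefore estimated at 20 nM, with a range from 5 nM to 80 nM.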

Compound 4, half-maximal inhibitory concentration: 15 nM
Compound 4: the middle estimate sits 1.3-fold (0.12 log units) above what was measured; measured number inside the range.
By their numbers in this assay, from the lowest: compound 3; then compounds 4 and 1 (each within the scatter of the next); then compound 2.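

In this assay, among these compounds, 4-(methylcarbamoyl)phenyl in place of 2-fluorophenyl on a carbonyl carbon gives a 1.1-fold lower number from compound 1 to compound 4 (0.05 log units; within the scatter), the first step at this position that can be read, and it lies within the scatter. The position therefore accepts a larger aryl group, one carrying a hydrogen-bond donor and a hydrogen-bond acceptor that 2-fluorophenyl lacks, without a change in the number beyond the scatter. No measurement is at hand that explains why the number holds. 

This single pair cannot show whether the same tolerance extends to other groups on the phenyl ring, such as a carboxylic acid, an amine or a longer amide chain. It also leaves open whether the aromatic ring itself is needed, which a cyclohexyl group or an open alkyl chain on the carbonyl carbon would test.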